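Trading a methylpiperidine for diethylamino

The source may report more compounds than this note shows. Statements on the series, on what has been measured and on what is new or still open speak of the compounds shown alone.

Of the compounds shown here, two have been measured so far. In a functional assay on MDA-MB-231 cells (Homo sapiens) for cytotoxicity, read by MTT assay, with a stated time of 72 h (on this read-out higher numbers stand for weaker inhibition and lower numbers for stronger inhibition), compound 1 (`CCN(CC)Cc1ccc2nc(NC(=O)N/N=C/c3cn(Cc4cccc(Cl)c4)c4ccccc34)sc2c1`) gives 2050 nM, and compound 2 (`CC1CCN(Cc2ccc3nc(NC(=O)N/N=C/c4cn(Cc5ccccc5Cl)c5ccccc45)sc3c2)CC1`) gives 1360 nM. These two values lie within the usual scatter of repeated measurements, so they cannot be ranked against each other.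

Compound 3 (`CCN(CC)Cc1ccc2nc(NC(=O)N/N=C/c3cn(Cc4ccccc4Cl)c4ccccc34)sc2c1`) departs from compound 2 in a single place: diethylamino in place of 4-methylpiperidin-1-yl on a saturated chain carbon bound to an aromatic carbon. In words, diethylamino stands in place of 4-methylpiperidin-1-yl on a saturated chain carbon bound to an aromatic carbon. Among the compounds with values here, no measured pair shows this change on its own, so the expectation rests on thin evidence. Compound 1, which also carries diethylamino, gives 2050 nM, close to compound 2 at 1360 nM. The expected 1.3-fold higher number from compound 2 to compound 3 (0.10 log units; within the scatter) therefore stays within the scatter in this assay. For compound 3 the estimated value is 1700 nM, with an expected range from 800 nM to 3600 nM.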

Compound 3, half-maximal inhibitory concentration: 900 nM
For compound 3 the middle estimate is 1.9-fold (0.28 log units) above the measured one, and the stated range covers the measured number.
By their numbers in this assay, from the lowest: compounds 3, 2 and 1 (each within the scatter of the next, the first and the last beyond it).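

In this assay, a 1.5-fold lower number from compound 2 to compound 3 (0.18 log units; within the scatter) does not separate diethylamino from 4-methylpiperidin-1-yl, so on this saturated chain carbon the two amines cannot be ranked. Within the data shown here, the other comparison concerns a different place: with 2-chlorophenyl in place of 3-chlorophenyl on a saturated chain carbon bound to an aromatic nitrogen, the result is a 2.3-fold lower number from compound 1 to compound 3 (0.36 log units; beyond the scatter), the only step here that passes the scatter, though modestly and on a single pair. Nothing available explains either result.

The compounds shown leave open how 4-chlorophenyl or an unsubstituted phenyl would compare on that carbon, and whether the chlorophenyl step would hold alongside 4-methylpiperidin-1-yl. They also leave open whether another ring amine, such as morpholin-4-yl, would read apart from the two amines seen here.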